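From hydrogen to methoxy: an estimate for compound 3

The compounds below may be only part of what the source reports. "The series", "measured", "known", "first", "only" and "open" are said of these compounds alone.

Compound 1 `O=C(/C=C/c1ccc(Cl)cc1)Nc1nc2ccc(Cl)cc2s1` gives 204 umol/kg
Compound 2 `O=C(/C=C/c1ccccc1)Nc1nc2ccc(Cl)cc2s1` gives 425 umol/kg
Compound 3 `COc1ccc(/C=C/C(=O)Nc2nc3ccc(Cl)cc3s2)cc1` is not yet measured

Both measured compounds were tested in a functional assay on the whole organism (Hindlimb, strain albino) with Mus musculus as the target, in the maximal electroshock model, with a stated time of 0.5 h; a higher number here means that more compound is needed for the effect, a lower number that less compound is needed. Compound 2 stands highest of the two, so more of it is needed for the effect. The next change is methoxy in place of hydrogen on an aromatic carbon, which puts methoxy in place of hydrogen on an aromatic carbon. Among the compounds with values here, only one measured step bears on this: with hydrogen in place of chloro, there is a 2.1-fold higher number from compound 1 to compound 2 (0.32 log units; beyond the scatter). That step is modest, and it involves a different group, so it is only a rough guide. It suggests that a group other than hydrogen may lower the number slightly. The expected change is a 1.4-fold lower number from compound 2 to compound 3 (0.15 log units; within the scatter). For compound 3 the estimated value is 300 umol/kg, with an expected range from 130 umol/kg to 700 umol/kg.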

Compound 3, dose for half-maximal effect: 259 umol/kg
Compound 3: middle estimate off by 1.2-fold (0.06 log units), on the high side, and the stated range covers the measured number.
By their numbers in this assay, from the lowest: compounds 1, 3 and 2 (each within the scatter of the next, the first and the last beyond it).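

Putting methoxy on this aromatic carbon, para to a large group, gives a 1.6-fold lower number from compound 2 to compound 3 (0.22 log units; within the scatter) in this assay, so at this place methoxy cannot be told apart from hydrogen. Swapping chloro for methoxy gives a 1.3-fold higher number from compound 1 to compound 3 (0.10 log units; within the scatter), so methoxy cannot be told apart from chloro either, even though chloro and hydrogen differ beyond the scatter. With methoxy sitting within the scatter of both, this position now shows a small range of numbers rather than a clear ordering of groups, and nothing measured here gives a reason for these numbers.

Still open, going by these compounds, is whether an amine or a carboxylic acid at this place would move the number beyond the scatter from compound 2. Also open, on these data alone, is whether a longer chain in place of methoxy would do so.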